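The source may report more compounds than this note shows. Statements on the series, on what has been measured and on what is new or still open speak of the compounds shown alone.

Measured compounds:
compound 1 `Cc1cccc2cc3c(nc12)-c1nc2ccccc2n1C3` gives 23800 nM in a functional assay on LNCaP cells (Homo sapiens) for cytotoxicity, read by MTT assay, with a stated time of 72 h; a lower number here means a stronger inhibitor, a higher number a weaker inhibitor;
compound 2 `Cc1ccc2cc3c(nc2c1)-c1nc2ccccc2n1C3` gives 39000 nM in this assay;
compound 3 `COc1cccc2cc3c(nc12)-c1nc2ccccc2n1C3` gives 20000 nM in this assay.

The three values lie within the scatter of one another, so none is singled out. Compound 1 and compound 2 share the same atoms joined differently; the difference between the two cores is not broken down here. From compound 1 to compound 3 the change is methoxy in place of methyl on an aromatic carbon, and in this assay it made a 1.2-fold lower number from compound 1 to compound 3 (0.08 log units; within the scatter). Compound 4 `COc1ccc2cc3c(nc2c1)-c1nc2ccccc2n1C3` is not yet measured. It stands to compound 2 as compound 3 stands to compound 1: methoxy in place of methyl on an aromatic carbon. This is the same kind of change, though the place differs: in compound 3 it is ortho to a fused ring and meta to a fused ring, in compound 4 meta to a fused ring and para to a fused ring. Because the step of a 1.2-fold lower number from compound 1 to compound 3 (0.08 log units; within the scatter) was within the scatter, the step to compound 4 is expected to be a 1.2-fold lower number from compound 2 to compound 4 (0.07 log units; within the scatter), likewise within the scatter. Compound 4 is therefore estimated at 33000 nM, most likely between 15000 nM and 70000 nM.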

Compound 4, half-maximal inhibitory concentration: 25000 nM
Compound 4: middle estimate off by 1.3-fold (0.12 log units), on the high side; measured number inside the range.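

On the second core, methoxy in place of methyl on an aromatic carbon gave a 1.6-fold lower number from compound 2 to compound 4 (0.19 log units; within the scatter) in this assay. Set beside the step on the first core, the change carried over with no difference that can be told apart: the same change on two cores in this assay, a 1.2-fold lower number (0.08 log units; within the scatter) from compound 1 to compound 3 and a 1.6-fold lower number (0.19 log units; within the scatter) from compound 2 to compound 4, 1.3-fold (0.12 log units) apart, within the scatter of two such steps. Going by these compounds alone, this shows only that the swap stayed within the scatter on both cores, with the group at a different place on each; it does not show that methoxy has an effect of its own, or that a larger step would carry over in the same way.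

The compounds shown leave open whether an amine, a carboxylic acid or a longer chain on this aromatic carbon would move the number beyond the scatter. They also leave open whether either core would respond differently to such a group.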